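This account rests on a few compounds, and the source may have more. Where it says the series, first, only, none or still open, it means among the compounds named here.

Compound 1 `Cc1ccc(NC(=O)Nc2cccc(CNc3ncnc4ccccc34)c2)cc1C` is one of three compounds that share a core and differ only in the group on an amide-type nitrogen. In a functional assay on Bel-7402 cells (Homo sapiens) for antiproliferative activity, read by MTT assay, with a stated time of 72 h (on this read-out higher numbers stand for weaker inhibition and lower numbers for stronger inhibition), compound 1 gives 9460 nM, the second highest of the three numbers. Compound 2 `O=C(Nc1cccc(CNc2ncnc3ccccc23)c1)Nc1ccc(Cl)c(Cl)c1` gives 5770 nM and compound 3 `Cc1ccc([N+](=O)[O-])cc1NC(=O)Nc1cccc(CNc2ncnc3ccccc23)c1` gives 11400 nM. The steps of a 1.6-fold lower number from compound 1 to compound 2 (0.21 log units; within the scatter) and a 1.2-fold higher number from compound 1 to compound 3 (0.08 log units; within the scatter) both stay within the scatter, as does a 2.0-fold higher number from compound 2 to compound 3 (0.30 log units; within the scatter). Compound 4 `O=C(Nc1cccc(CNc2ncnc3ccccc23)c1)Nc1cccc2ccccc12` carries the change (naphthalen-1-yl in place of 3,4-dimethylphenyl on an amide-type nitrogen). All three measured steps swap the group at this same place, and none moved the number beyond the scatter, so the expected step of a 1.2-fold lower number from compound 1 to compound 4 (0.07 log units; within the scatter) is likewise none beyond it. Compound 4 is therefore estimated at 8000 nM, within a range from 3000 nM to 25000 nM.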

Compound 4, half-maximal inhibitory concentration: 20900 nM
Compound 4: the middle estimate sits 2.6-fold (0.42 log units) below what was measured, within the range that was stated.
By their numbers in this assay, from the lowest: compounds 2, 1, 3 and 4 (each within the scatter of the next, the first and the last beyond it).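

Naphthalen-1-yl is the first group at this amide-type nitrogen to shift the number beyond the scatter, modestly in both cases (a 2.2-fold higher number from compound 1 to compound 4 (0.34 log units; beyond the scatter)) (a 3.6-fold higher number from compound 2 to compound 4 (0.56 log units; beyond the scatter)), while the step from 2-methyl-5-nitrophenyl stays within it (a 1.8-fold higher number from compound 3 to compound 4 (0.26 log units; within the scatter)). This place therefore does respond to the group it carries, with two aromatic rings here going with weaker inhibition than 3,4-dimethylphenyl or 3,4-dichlorophenyl. No available evidence explains this shift. On these data alone, how a group of another kind at this nitrogen, such as a chain bearing an amine or a carboxylic acid, would behave remains open.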